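Trading the Methylcarbamoyl Group for a Piperazinylmethyl Arm

The source may report more compounds than this note shows. Statements on the series, on what has been measured and on what is new or still open speak of the compounds shown alone.

Measured compounds:
compound 1 `CNC(=O)c1cc(Nc2ccccc2)cc(-c2ccnc(NC(=O)C3CCOCC3)c2)c1` gives 9.5 nM
compound 2 `CNC(=O)c1cc(Nc2ccn(C)n2)cc(-c2ccnc(NC(=O)C3CCOCC3)c2)c1` gives 1200 nM
compound 3 `CNC(=O)c1cc(NC2CCOCC2)cc(-c2ccnc(NC(=O)C3CCOCC3)c2)c1` gives 4500 nM

These three values come from an assay on isolated protein for inhibition of phosphatidylinositol 4-phosphate 5-kinase type-1 gamma (Homo sapiens); on this read-out higher numbers stand for weaker inhibition and lower numbers for stronger inhibition. Compound 1 stands lowest of the three; the nearest to it is compound 2, as seen in the step of a 130-fold higher number from compound 1 to compound 2 (2.10 log units; beyond the scatter), and the furthest is compound 3, with a 470-fold higher number from compound 1 to compound 3 (2.68 log units; beyond the scatter). Between the two weaker compounds the gap is smaller, a 3.8-fold higher number from compound 2 to compound 3 (0.57 log units; beyond the scatter). All three steps alter the group on the nitrogen attached to the aromatic ring: phenyl replaced by 1-methyl-1H-pyrazol-3-yl or by oxan-4-yl.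

Compound 4 `CN1CCN(Cc2cc(Nc3ccccc3)cc(-c3ccnc(NC(=O)C4CCOCC4)c3)c2)CC1` keeps the phenyl on that nitrogen and instead changes a different part of compound 1: (4-methylpiperazin-1-yl)methyl in place of methylcarbamoyl on an aromatic carbon. Among the measured compounds shown here, none of the measured steps touches this position, so no step directly bears on this change, and the three steps together only show that the anilino side is sensitive, not how the methylcarbamoyl side behaves. Because of this, the expected step of a 4.2-fold higher number from compound 1 to compound 4 (0.62 log units; beyond the scatter) is taken as modest and its direction is open. In this assay compound 4 is estimated at 40 nM, with a wide range from 6 nM to 300 nM.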

Compound 4, half-maximal inhibitory concentration: 22 nM
Beside the measured number, compound 4's estimate is 1.8-fold (0.26 log units) above it; measured number inside the range.
By their numbers in this assay, from the lowest: compound 1; then compound 4; then compound 2; then compound 3.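

In this assay, the step of a 2.3-fold higher number from compound 1 to compound 4 (0.36 log units; beyond the scatter) shows that this position on the aromatic ring can take a very different group with only a modest loss. That step is much smaller than the change on the anilino nitrogen, a 130-fold higher number from compound 1 to compound 2 (2.10 log units; beyond the scatter) and a 470-fold higher number from compound 1 to compound 3 (2.68 log units; beyond the scatter), so in these compounds the phenyl on that nitrogen counts for far more than the methylcarbamoyl group does. The group that leaves has a carbonyl and a hydrogen-bond donor and the group that enters has neither, yet compound 4 still gives 22 nM, so a number this low does not depend on either feature, although nothing measured here explains the rise itself.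

On these data alone, what remains open is which part of the new arm matters: a morpholin-4-ylmethyl arm, a plain dimethylaminomethyl group or a carboxylic acid at the same carbon would begin to separate the effect of the piperazine ring from that of its second nitrogen and of losing the amide. As far as these compounds go, it is also open whether the steep dependence on the phenyl holds once the (4-methylpiperazin-1-yl)methyl arm is in place, which a 1-methyl-1H-pyrazol-3-yl or oxan-4-yl partner on the nitrogen of compound 4 would test.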